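Replacing the Pyridinylmethyl Arm in Compound 1 with Fluorophenyl

The source may report more compounds than this note shows. Statements on the series, on what has been measured and on what is new or still open speak of the compounds shown alone.

Of the compounds shown here, three sharing one core have been tested in a functional assay on HeLa cells (Homo sapiens) for antiproliferative activity, read by CCK-8 assay, with a stated time of 72 h, tested at 8 uM; on this read-out lower numbers stand for a weaker effect and higher numbers for a stronger effect at the one concentration tested. Compound 1 `Nc1ccccc1NC(=O)c1ccc(CSC(=S)N2CCN(Cc3ccccn3)CC2)cc1` gives 61.4%, the second highest of the three numbers. Compound 2 `Nc1ccccc1NC(=O)c1ccc(CSC(=S)N2CCc3ccc([N+](=O)[O-])cc32)cc1` gives 62.1%, which lies within the usual scatter of the number for compound 1, so the two cannot be told apart. Compound 3 `Nc1ccccc1NC(=O)c1ccc(CSC(=S)N2CCN(C(c3ccccc3)c3ccccc3)CC2)cc1` gives 13.8%, far below compound 1 and beyond the scatter. Compound 4 `Nc1ccccc1NC(=O)c1ccc(CSC(=S)N2CCN(c3ccccc3F)CC2)cc1` has not yet been measured; it differs from compound 1 by 2-fluorophenyl in place of (pyridin-2-yl)methyl on an amine nitrogen in a ring. Within the data shown here, no pair of measured compounds isolates a change of this kind, so the direction of the step is uncertain. A downward step of moderate size from compound 1 is expected, a number 16.4 percentage points lower from compound 1 to compound 4 (beyond the scatter), smaller than the fall seen for compound 3 at 13.8%. Compound 4 is therefore estimated at 45%, with a range from 20% to 68%.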

Compound 4, a percentage reported as inhibition, at one concentration (the size of the read-out at that concentration, not a potency): 59.2%
The estimate for compound 4 lay 14.2 percentage points below the measured number, within the range that was stated.
By their numbers in this assay, from the lowest: compound 3; then compounds 4, 1 and 2 (each within the scatter of the next).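

In this assay the swap at this amine nitrogen gives a number 2.2 percentage points lower from compound 1 to compound 4 (within the scatter) on the shared core. This position therefore accepts 2-fluorophenyl in place of (pyridin-2-yl)methyl, and the ring nitrogen of the departing group is not required to keep this level of effect. No measured evidence gives a reason for this result. From the compounds shown here alone, whether the fluorine contributes anything remains open, since plain phenyl and benzyl on the same nitrogen are absent from these compounds. A single concentration also leaves the potency of compound 1 and compound 4 unknown.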